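Removing trifluoromethoxy: compound 1 to compound 4

A few compounds are considered here, and "the series" means these few. Any claim that something is new, unique, unknown or untested is made for them only; others in the source may bear on it.

Series in a functional assay on KG-1 cells (Homo sapiens) for cytotoxicity, read by luminescence and CellTiter-Glo, with a stated time of 3 days; a lower number here means a stronger inhibitor, a higher number a weaker inhibitor:
- compound 1 `O=C(Nc1ccc(OC(F)(F)F)cc1)c1cc(F)ccc1O`: 780 nM
- compound 2 `O=C(Nc1ccc(OC(F)(F)F)c(Cl)c1)c1cc(F)ccc1O`: 370 nM
- compound 3 `COc1cccc(C(=O)Nc2ccc(C#N)cc2)c1O`: > 10000 nM
- compound 4 `O=C(Nc1ccccc1)c1cc(F)ccc1O`: not yet measured

Within the data shown here, only two entries are true numbers, and compound 1 holds the higher of them. For compound 3, the entry > 10000 nM is a limit of the assay and not a number.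

The step in question takes compound 1 to compound 4: hydrogen in place of trifluoromethoxy on an aromatic carbon. Among the measured compounds shown here, only one measured step bears on it, a substituent gained on an aromatic carbon, which gave a 2.1-fold lower number from compound 1 to compound 2 (0.32 log units; beyond the scatter). That step is modest and involves a different group, so it offers only a loose guide. It suggests that an added substituent can lower the number, so taking one away is expected to raise it. In this assay, the expected change is larger than that measured step: a 4.5-fold higher number from compound 1 to compound 4 (0.65 log units; beyond the scatter) is the estimate. The estimated value for compound 4 is 3500 nM, with an expected range of 1200 nM to 10000 nM. A reading at the limit of the assay remains possible.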

Compound 4, half-maximal inhibitory concentration: > 10000 nM
Compound 4 ended at the assay's limit; the forecaster's own chance of this, stated with the estimate: 20%; middle value at least 2.8-fold (0.45 log units) away from the limit.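

In this assay, the first direct test of the trifluoromethoxy position shows that activity depends strongly on a substituent there: hydrogen in place of that group gives an at least 12-fold higher number from compound 1 to compound 4 (1.10 log units; beyond the scatter). The entry for compound 4, > 10000 nM, is a limit of the assay and not a number. The step therefore sets only a minimum size, and its true size remains unknown: the limit of > 10000 nM in this assay, at which 2 of the 4 values shown sit.

From the compounds shown here alone, whether other substituents at this position, such as methoxy, chlorine or an amine, would keep the number close to that of compound 1, 780 nM, remains open. Compound 3 differs from compound 4 in more than one place, so it cannot show which feature of the shared amide framework matters alongside this position.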